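This account rests on a few compounds, and the source may have more. Where it says the series, first, only, none or still open, it means among the compounds named here.

Working notes on the series. All numbers come from a functional assay on DU-145 cells (Homo sapiens) for inhibition, read by trypan blue exclusion, with a stated time of 96 h; a lower number here means a stronger inhibitor of growth, a higher number a weaker inhibitor of growth.

Measured so far:
- compound 1 `Cc1ccc(CS/C(=C/c2c[nH]c3ccc(Cl)cc23)C(=O)c2ccc(Cl)cc2)cc1` gives 1000 nM
- compound 2 `COc1ccccc1/C=C(/SCc1ccc(C)cc1)C(=O)c1ccc(Cl)cc1` gives 10000 nM
- compound 3 `Cc1ccc(CS/C(=C/c2c(O)cc(O)cc2O)C(=O)c2ccc(Cl)cc2)cc1` gives 50000 nM

Compound 2 holds the second highest of the three numbers. Its nearest neighbour is compound 3, reached by a 5.0-fold higher number from compound 2 to compound 3 (0.70 log units; beyond the scatter); its furthest is compound 1, which stands at a 10-fold higher number from compound 1 to compound 2 (1.00 log units; beyond the scatter) on the other side. The third measured step, a 50-fold higher number from compound 1 to compound 3 (1.70 log units; beyond the scatter), is the largest in the set.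

Compound 4 `COc1ccccc1/C=C(/SCc1ccccc1F)C(=O)c1ccc(Cl)cc1` is the next compound to go into this assay. It differs from compound 2 in a single place:

2-fluorophenyl in place of 4-methylphenyl on a saturated chain carbon bound to a sulfur

Among the measured compounds shown here, every measured step so far changes the group on the double-bonded chain carbon; no step touches the (4-methylbenzyl)sulfanyl side of the core. The measured data therefore give no direct reading on what 4-methylphenyl to 2-fluorophenyl on the saturated chain carbon bound to a sulfur should do. With no guidance, the expectation for compound 4 is a number close to that of compound 2, that is, no change at the digits printed from compound 2 to compound 4 (within the scatter) is estimated to stay within the usual scatter. Compound 4 is accordingly expected to give about 10000 nM in this assay, with a likely range from 4000 nM to 25000 nM.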

Compound 4, concentration for 50% growth inhibition: 10000 nM
The estimate for compound 4 equals the measured number at the digits printed; measured number inside the range.
By their numbers in this assay, from the lowest: compound 1; then compounds 2 and 4 (each within the scatter of the next); then compound 3.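

In this assay, among the compounds shown here, the first change on the sulfur side of the core, 2-fluorophenyl in place of 4-methylphenyl on a saturated chain carbon bound to a sulfur, reads as no change at the digits printed from compound 2 to compound 4 (within the scatter). With the 2-methoxyphenyl group held constant, this position therefore accepts this exchange without a shift beyond the scatter, whereas the change on the double-bonded chain carbon reads as a 10-fold higher number from compound 1 to compound 2 (1.00 log units; beyond the scatter). No available data bear on why the number holds at this position.

For the compounds shown here, the single step swaps the methyl group for fluorine and the 4-substituted ring for a 2-substituted one together, so the two parts of the change cannot be separated. Going by these compounds, it also remains open whether the same holds with the 5-chloro-1H-indol-3-yl group of compound 1, or with an amine, a carboxylic acid or a longer chain in place of 4-methylphenyl.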